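The source may hold more compounds than are shown below. What is called first, only, known or untested is meant among the compounds shown, and "the series" means these compounds.

Compound 1 `O=c1cc(-c2ccccc2)oc2c(OCCCCNC3CCCCC3)c(O)cc(O)c12` carries a cyclohexylamine-capped chain on its shared core, yet in a functional assay on A549 cells (Homo sapiens) for cytotoxicity, read by MTT assay, with a stated time of 48 h (a lower number here means a stronger inhibitor, a higher number a weaker inhibitor), compound 1 is reported as "not determined" (no result reported), so its standing cannot be placed. A close relative, compound 2 `COc1c(OCCCCN2CCCC2)cc(O)c2c(=O)cc(-c3ccccc3)oc12`, gives 1530 nM in this assay, the only anchor here. Compound 3 `CN(C)CCCOc1c(O)cc(O)c2c(=O)cc(-c3ccccc3)oc12` differs from compound 1 by one change: dimethylamino in place of (cyclohexylamino)methyl on a saturated chain carbon, three bonds along the chain from an oxygen on an aromatic ring. Going by the values given here, with no measured pair to calibrate this change, the step from compound 1 to compound 3 in this assay is expected to be small, likely within the usual scatter, and in no firm direction. For compound 3 in this assay the expected value is 3000 nM, within a range of 800 nM to 12000 nM.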

Compound 3, half-maximal inhibitory concentration: > 100000 nM
Compound 3: a limit, no number (the forecaster's own chance of this, stated with the estimate: 10%); middle value at least 33-fold (1.52 log units) away from the limit.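

Going by these compounds alone, compound 1 has no reported result in this assay and compound 3 gives only a limit, so no step between them can be read. The compounds shown leave open what replacing (cyclohexylamino)methyl with dimethylamino does in this assay.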